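The source may hold more compounds than are shown below. What is called first, only, known or untested is meant among the compounds shown, and "the series" means these compounds.

Measured so far in a functional assay on HeLa cells (Homo sapiens) for antiproliferative activity, read by MTT assay, with a stated time of 48 h; a higher number here means a weaker inhibitor, a lower number a stronger inhibitor:
compound 1, `COc1ccccc1C(=O)Nc1nnc(SCC(=O)Nc2ccc(C)cn2)s1`: > 80000 nM
compound 2, `O=C(CSc1nnc(NC(=O)CCl)s1)Nc1ccc(Cl)cn1`: 3600 nM
compound 3, `O=C(CSc1nnc(NC(=O)CCl)s1)Nc1ccc(Br)cn1`: 3400 nM

The value of compound 1 is a limit of this assay, not a number (the limit of > 80000 nM in this assay, at which 1 of the 3 values shown sits). Compound 3 gives 3400 nM and compound 2 gives 3600 nM; the step of a 1.1-fold lower number from compound 2 to compound 3 (0.02 log units; within the scatter) keeps the two within the scatter of each other, so neither is set apart from the other.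

Compound 4, `Cc1ccc(NC(=O)CSc2nnc(NC(=O)CCl)s2)nc1`, differs from compound 3 in one place: methyl in place of bromo on an aromatic carbon. Going by the values given here, the only measured step at this ring carbon is a 1.1-fold lower number from compound 2 to compound 3 (0.02 log units; within the scatter), an exchange of one halogen for another, and it made no difference beyond the scatter. Among the compounds with values here, no measured step exchanges a halogen for methyl. Within the data shown here, compound 1 carries the same methyl but a different acyl group on the shared core, and its value is a limit, so it gives no step to compute.

The expectation for compound 4 is therefore a small shift, a 1.5-fold higher number from compound 3 to compound 4 (0.17 log units; within the scatter), leaning toward a somewhat higher number. Compound 4 is estimated at 5000 nM, with a range from 1500 nM to 20000 nM.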

Compound 4, half-maximal inhibitory concentration: 10900 nM
The estimate for compound 4 lay 2.2-fold (0.34 log units) below the measured number; the measured number falls inside the stated range.
By their numbers in this assay, from the lowest: compounds 3 and 2 (each within the scatter of the next); then compound 4. At a limit, above all of these: compound 1.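

At this ring carbon the group does matter in this assay: the exchange of one halogen for the other stayed within the scatter, but methyl gives a 3.2-fold higher number from compound 3 to compound 4 (0.51 log units; beyond the scatter) and a 3.0-fold higher number from compound 2 to compound 4 (0.48 log units; beyond the scatter), both modest steps. The change to the 5-methylpyridin-2-yl group thus sets compound 4 apart from both halogen compounds, while compound 2 and compound 3 stay together. With that methyl held, chloromethyl in place of 2-methoxyphenyl on the carbonyl carbon gives an at least 7.3-fold lower number from compound 1 to compound 4 (0.86 log units; beyond the scatter), a step that starts from a limit and not from a number: the limit of > 80000 nM in this assay, at which 1 of the 4 values shown sits.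

On these data alone, whether an amine, a methoxy group or a trifluoromethyl group at this ring carbon would sit with the halogens or with methyl remains open. Also open, as far as these compounds go, is how a plain methyl or a longer chain on the carbonyl carbon would compare with chloromethyl.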